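Working notes: from compound 2 to compound 3

This account rests on a few compounds, and the source may have more. Where it says the series, first, only, none or still open, it means among the compounds named here.

Measured so far in a functional assay on SGC-7901 cells (Homo sapiens) for antiproliferative activity, read by MTT assay, with a stated time of 24 h (a higher number here means a weaker inhibitor, a lower number a stronger inhibitor), as the read-out

- Compound 1 `O=C(NNc1ccc(F)cc1)c1ccccc1NS(=O)(=O)c1cnc(O)nc1O` gives > 20000 nM as a limit
- Compound 2 `Cc1ccc(C(=O)NNC(=O)c2ccccc2NS(=O)(=O)c2cnc(O)nc2O)cc1` gives 15500 nM as a number

Compound 1 gives only a limit, namely the limit of > 20000 nM in this assay, at which 1 of the 2 values shown sits, and not a number.

For the measured compounds named here, compound 2 holds the only number in this assay so far.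

Compound 3 `O=C(NNC(=O)c1ccccc1NS(=O)(=O)c1cnc(O)nc1O)c1ccccc1Cl` carries 2-chlorophenyl in place of 4-methylphenyl on a carbonyl carbon.

Going by the values given here, no measured step changes a group at this carbonyl carbon. The nearest guide is an at least 1.2-fold lower number from compound 1 to compound 2 (0.11 log units; that floor lies within the scatter) which concerns a group on an amine nitrogen and gives only a floor. On that step alone, no change beyond the scatter is expected in this assay and neither direction is favoured. The expected step is a 1.0-fold higher number from compound 2 to compound 3 (0.01 log units; within the scatter) and it stays within the scatter. For compound 3 the estimated value is 16000 nM with an expected range from 8000 nM to 30000 nM in this series.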

Compound 3, half-maximal inhibitory concentration: 2410 nM
Beside the measured number, compound 3's estimate is 6.6-fold (0.82 log units) above it, and the stated range ends above it.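

Exchanging 4-methylphenyl for 2-chlorophenyl on a carbonyl carbon gives a 6.4-fold lower number from compound 2 to compound 3 (0.81 log units; beyond the scatter) in this assay. This place therefore responds to the choice of aromatic group, even though the two groups match in heavy atoms, ring type and hydrogen-bond donor and acceptor counts. Placing (2-chlorophenyl)carbonyl where 4-fluorophenyl sits on an amine nitrogen gives an at least 8.2-fold lower number from compound 1 to compound 3 (0.91 log units; beyond the scatter), which lies beyond the scatter, whereas the floor for (4-methylphenyl)carbonyl at that nitrogen lay within it, and compound 1 gives a limit and not a number, so this step too is a floor: the limit of > 20000 nM in this assay, at which 1 of the 3 values shown sits.

From the compounds shown here alone, whether the lower number follows the chlorine or its location on the ring remains open, and a 2-methylphenyl or 4-chlorophenyl group on this carbonyl carbon would separate the two. Also open, going by these compounds, is how an amine or a carboxylic acid would read on the same carbonyl-bearing ring, and whether the step between these two groups holds in any other cell line.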